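The source may report more compounds than this note shows. Statements on the series, on what has been measured and on what is new or still open speak of the compounds shown alone.

Working notes on the series.

The shared core is carried by compound 1 `Cn1c(Cc2nn(C)c(=O)c3ccccc23)nnc1SCCCCCCCC(=O)Nc1ccc(Cl)cc1Cl`, which in an assay on 32D cells for inhibition of interleukin-15 (Mus musculus), read by resazurin assay, with stated times of 30 min and 2.5 days, in the presence of a further agent that is not named here (on this read-out higher numbers stand for weaker inhibition and lower numbers for stronger inhibition), gives 3900 nM. Compound 2 `CN(C)CCCn1c(Cc2nn(C)c(=O)c3ccccc23)nnc1SCCCCCCCC(=O)Nc1ccc(Cl)cc1Cl` differs by 2-(dimethylamino)ethyl in place of hydrogen on a saturated chain carbon bound to an aromatic nitrogen, and in this assay compound 2 gives 5500 nM; the step of a 1.4-fold higher number from compound 1 to compound 2 (0.15 log units; within the scatter). Compound 3 `Cn1c(Cc2nn(CCCO[Si](C)(C)C(C)(C)C)c(=O)c3ccccc23)nnc1SCCCCCCCC(=O)Nc1ccc(Cl)cc1Cl` instead carries a silyl-bearing chain on a saturated chain carbon bound to an aromatic nitrogen. In this assay compound 3 gives > 30000 nM, which is a limit of the assay and not a number (the limit of > 30000 nM in this assay, at which 1 of the 3 values shown sits). On the values shown, compound 3 therefore stands only at that limit, with the step of an at least 7.6-fold higher number from compound 1 to compound 3 (0.88 log units; beyond the scatter).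

Compound 4 `CN(C)CCCn1nc(Cc2nnc(SCCCCCCCC(=O)Nc3ccc(Cl)cc3Cl)n2C)c2ccccc2c1=O` follows from compound 3 by the change (a group of 3 heavy atoms (2 carbon, 1 nitrogen; no ring) in place of a group of 8 heavy atoms (6 carbon, 1 oxygen, 1 silicon; no ring), on a saturated chain carbon, three bonds along the chain from an aromatic nitrogen). For the measured compounds named here, two measured steps bear on it: the step from compound 1 to compound 3 shows that adding the silyl-bearing chain cost potency beyond the scatter, and the step from compound 1 to compound 2 shows that a dimethylamino-bearing chain on an aromatic nitrogen was tolerated within the scatter. Removing the silyl group is therefore expected to recover most of that loss, and the estimated step of an at least 5.0-fold lower number from compound 3 to compound 4 (0.69 log units; beyond the scatter). Compound 4 is expected to give about 6000 nM, within 2000 nM to 30000 nM.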

Compound 4, half-maximal inhibitory concentration: 3200 nM
Compound 4: middle estimate off by 1.9-fold (0.27 log units), on the high side; low and high end bracket the measured number.
By their numbers in this assay, from the lowest: compounds 4, 1 and 2 (each within the scatter of the next). At a limit, above all of these: compound 3.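

The silyl-bearing end of the chain, not the chain itself, goes with the loss on this aromatic nitrogen: with dimethylamino in its place, this assay gives an at least 9.3-fold lower number from compound 3 to compound 4 (0.97 log units; beyond the scatter). Compound 3 stands at a limit of the assay and not at a number: the limit of > 30000 nM in this assay, at which 1 of the 4 values shown sits. Measured against the core of compound 1, 2-(dimethylamino)ethyl at this place gives a 1.2-fold lower number from compound 1 to compound 4 (0.09 log units; within the scatter), so this place tolerates the dimethylamino-ended chain in this assay, which compound 3 alone could not show and which compound 2 showed only for a different place on the shared core.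

What the compounds shown leave open is how far this tolerance reaches at the end of the chain: whether a morpholine, a free hydroxyl, a carboxylic acid or a longer chain would stay level with compound 1 or move away from it. On these data alone, neither of the dimethylamino compounds moves beyond the scatter from compound 1, so whether any group at this place can strengthen inhibition also remains open.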